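Bromo for methoxy across two sulfonamide cores

A few compounds are considered here, and "the series" means these few. Any claim that something is new, unique, unknown or untested is made for them only; others in the source may bear on it.

Measured in a functional assay on MCF7 cells (Homo sapiens) for antiproliferative activity, read by MTT assay; on this read-out lower numbers stand for stronger inhibition and higher numbers for weaker inhibition:
- compound 1 `NS(=O)(=O)c1ccc(/N=C2\NC(=O)/C(=C3/C(=O)Nc4ccc(Br)cc43)S2)cc1` gives 11300 nM
- compound 2 `COc1ccc2c(c1)/C(=C1/S/C(=N/c3ccc(S(N)(=O)=O)cc3)NC1=O)C(=O)N2` gives 125000 nM
- compound 3 `COc1ccc2c(c1)/C(=C1/S/C(=N/c3cccc(S(N)(=O)=O)c3)NC1=O)C(=O)N2` gives > 200000 nM

The value of compound 3 is a limit of the assay, not a number; this is the limit of > 200000 nM in this assay, at which 1 of the 3 values shown sits. Compound 3 and compound 2 have the same atoms joined differently; the difference between the two cores is not broken down here.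

From compound 2 to compound 1 the change is bromo in place of methoxy on an aromatic carbon, and in this assay it gave an 11-fold lower number from compound 2 to compound 1 (1.04 log units; beyond the scatter).

Compound 4 `NS(=O)(=O)c1cccc(/N=C2\NC(=O)/C(=C3/C(=O)Nc4ccc(Br)cc43)S2)c1` is not yet measured. It stands to compound 3 as compound 1 stands to compound 2: the change is bromo in place of methoxy on an aromatic carbon, the same change at the same place. Because compound 3 only shows (the limit of > 200000 nM in this assay, at which 1 of the 3 values shown sits), the starting point is uncertain, so the expected step of an at least 5.0-fold lower number from compound 3 to compound 4 (0.69 log units; beyond the scatter) from compound 3 to compound 4 in this assay rests on the size of an 11-fold lower number from compound 2 to compound 1 (1.04 log units; beyond the scatter) alone, carried over from the core of compound 2. On that basis compound 4 is estimated at 40000 nM in this assay, with a range from 10000 nM to 200000 nM expected.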

Compound 4, half-maximal inhibitory concentration: > 200000 nM
Compound 4 ended at the assay's limit; the forecaster's own chance of this, stated with the estimate: 30%; middle value at least 5.0-fold (0.69 log units) from the limit.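

In this assay compound 4 gives > 200000 nM, a limit of the assay and not a number. Compound 3 also stands at a limit, and no step from compound 3 to compound 4 can be read: the limit of > 200000 nM in this assay, at which 2 of the 4 values shown sit.

The compounds shown leave open whether bromo in place of methoxy changes anything on the core of compound 3.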